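The source may report more compounds than this note shows. Statements on the series, on what has been measured and on what is new or still open speak of the compounds shown alone.

In a functional assay on HUVEC cells (Homo sapiens) for antiproliferative activity, read by MTT assay, with a stated time of 48 h (a higher number here means a weaker inhibitor, a lower number a stronger inhibitor), three compounds with a shared core have been measured. Compound 1 `O=[N+]([O-])c1ccc(/C=C/c2nnc(-c3ccc4c(c3)OCCO4)o2)cc1` gives 32100 nM, compound 2 `Fc1ccc(/C=C/c2nnc(-c3ccc4c(c3)OCCO4)o2)cc1` gives 4960 nM, and compound 3 `Fc1ccccc1/C=C/c1nnc(-c2ccc3c(c2)OCCO3)o1` gives 1160 nM, the lowest number of the three.

Compound 4 `Cc1ccccc1/C=C/c1nnc(-c2ccc3c(c2)OCCO3)o1` has not yet been measured. It differs from compound 3 at a single place: methyl in place of fluoro on an aromatic carbon. In words, this is methyl in place of fluoro on an aromatic carbon, so 2-fluorophenyl becomes 2-methylphenyl.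

Among the measured compounds shown here, no measured step makes this exact swap, so the evidence is indirect. Fluoro in place of nitro gave a 6.5-fold lower number from compound 1 to compound 2 (0.81 log units; beyond the scatter), and 2-fluorophenyl in place of 4-fluorophenyl gave a 4.3-fold lower number from compound 2 to compound 3 (0.63 log units; beyond the scatter). Both steps are modest, yet both lie beyond the scatter, so a small change of substituent can matter in this series. Neither step shows which way methyl will go. The step expected is a 1.6-fold higher number from compound 3 to compound 4 (0.19 log units; within the scatter), a small rise that would stay within the scatter. The estimated value for compound 4 is 1800 nM, with an expected range from 600 nM to 6000 nM.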

Compound 4, half-maximal inhibitory concentration: 40500 nM
Estimate against measurement, compound 4: 23-fold (1.35 log units) below; measured number above the stated range.
By their numbers in this assay, from the lowest: compound 3; then compound 2; then compounds 1 and 4 (each within the scatter of the next).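

In this assay, this position proves highly sensitive: one heavy atom replaces another, with no ring, hydrogen-bond donor, hydrogen-bond acceptor or net charge entering or leaving, yet methyl in place of fluoro gives a 35-fold higher number from compound 3 to compound 4 (1.54 log units; beyond the scatter) and counts as a large step. The earlier gain therefore did not come from simply having a group ortho to a large group, since a 4.3-fold lower number from compound 2 to compound 3 (0.63 log units; beyond the scatter) points the opposite way from an 8.2-fold higher number from compound 2 to compound 4 (0.91 log units; beyond the scatter) and the identity of that group decides the direction. The data shown include no measurement that bears on the cause of this difference.

On these data alone, only fluoro and methyl are compared at this position, so it remains open where a chloro, a methoxy or an amine would fall. As far as these compounds go, it also remains open whether the same contrast between fluoro and methyl would appear on a different core.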